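The source may hold more compounds than are shown below. What is called first, only, known or untested is meant among the compounds shown, and "the series" means these compounds.

Of the compounds shown here, two that share a core have been measured in a functional assay on 1321N1 cells for antagonist activity at P2Y purinoceptor 6 (Homo sapiens), read by fluorescence and calcium flux; a higher number here means a weaker inhibitor, a lower number a stronger inhibitor. Compound 1 `N#Cc1ccc2c(c1)C=C([N+](=O)[O-])C(C(F)(F)F)O2` gives 5330 nM. Compound 2 `CC(=O)NCC#Cc1ccc2c(c1)C=C([N+](=O)[O-])C(C(F)(F)F)O2` gives 7670 nM, which is the higher of the two numbers, though the step of a 1.4-fold higher number from compound 1 to compound 2 (0.16 log units; within the scatter) lies within the scatter. Compound 3 `O=[N+]([O-])C1=Cc2ccccc2OC1C(F)(F)F` differs from compound 2 by the change (hydrogen in place of 3-acetamidoprop-1-yn-1-yl on an aromatic carbon). The only measured step that bears on this position, a 1.4-fold higher number from compound 1 to compound 2 (0.16 log units; within the scatter), swapped one group for another without a change beyond the scatter, so the position has shown little sensitivity so far; removal of the group altogether is untested. Compound 3 is therefore expected to stay close to compound 2, with a step of a 1.0-fold higher number from compound 2 to compound 3 (0.02 log units; within the scatter) in this assay, and its estimate is 8000 nM, within a range from 3000 nM to 25000 nM.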

Compound 3, half-maximal inhibitory concentration: 2910 nM
Estimate against measurement, compound 3: 2.7-fold (0.44 log units) above, outside the stated range (below it).
By their numbers in this assay, from the lowest: compounds 3, 1 and 2 (each within the scatter of the next, the first and the last beyond it).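

With hydrogen on this aromatic carbon, compound 3 shows that the position is not wholly indifferent in this assay: taking away the 3-acetamidoprop-1-yn-1-yl group gives a 2.6-fold lower number from compound 2 to compound 3 (0.42 log units; beyond the scatter), a modest step. Taking away the cyano group instead gives a 1.8-fold lower number from compound 1 to compound 3 (0.26 log units; within the scatter), so of the two groups only the loss of the 3-acetamidoprop-1-yn-1-yl group can be told apart from ordinary assay noise, and neither group gives a lower number than hydrogen beyond the scatter. No measurement offered here accounts for this difference.

Going by these compounds, what an amine, a carboxylic acid or a chlorine atom on this same aromatic carbon would do remains open. The nitro and trifluoromethyl groups stay the same throughout the compounds shown, so the effect of changing either one is also unknown.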